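The compounds below may be only part of what the source reports. "The series", "measured", "known", "first", "only" and "open" are said of these compounds alone.

Compound 1 `CCC(=O)N1N=C(c2ccccc2)CC1c1ccc(Cl)cc1` gives 100000 nM in an assay on isolated protein for inhibition of Amine oxidase [flavin-containing] B (Bos taurus) (a higher number here means a weaker inhibitor, a lower number a stronger inhibitor), level with compound 3 `CCC(=O)N1N=C(c2ccccc2)CC1c1ccc(C)cc1` at 100000 nM; together these two are the highest of the three numbers. Compound 2 `CCC(=O)N1N=C(c2ccccc2)CC1c1ccc(F)cc1` gives 1150 nM. The measured steps all exchange the group on the ring that carries chloro in compound 1: an 87-fold lower number from compound 1 to compound 2 (1.94 log units; beyond the scatter), whereas no change at the digits printed from compound 1 to compound 3 (within the scatter). Within the data shown here, compound 4 `CCC(=O)N1N=C(c2ccc(Cl)cc2)CC1c1ccc(Cl)cc1` differs from compound 1 by chloro in place of hydrogen on an aromatic carbon, the phenyl becoming 4-chlorophenyl, a place no measured step touches. The data therefore give no direct guide to this change. The expected step is a 1.7-fold lower number from compound 1 to compound 4 (0.22 log units; within the scatter), because compound 1 already sits at 100000 nM and nothing here suggests a large move. Compound 4 is accordingly estimated at 60000 nM, with a range from 10000 nM to 200000 nM.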

Compound 4, half-maximal inhibitory concentration: 10000 nM
Compound 4: middle estimate off by 6.0-fold (0.78 log units), on the high side, and the stated range covers the measured number.
By their numbers in this assay, from the lowest: compound 2; then compound 4; then compounds 1 and 3 (each within the scatter of the next).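

In this assay, among these compounds, the phenyl ring that no earlier step touched proves responsive: 4-chlorophenyl in place of phenyl gives a 10-fold lower number from compound 1 to compound 4 (1.00 log units; beyond the scatter), a step beyond the scatter. Compound 4 keeps the chloro of compound 1 on the other ring, so the number can move without changing that group. Nothing available explains this step.

The compounds shown leave open whether fluoro would give a similar step at this new position, and whether methoxy or an amine there would do the same. They also leave open how this change behaves in compound 2, which carries fluoro on the other ring.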